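The source may report more compounds than this note shows. Statements on the series, on what has been measured and on what is new or still open speak of the compounds shown alone.

Within the data shown here, compound 3 `O=C(NCCNS(=O)(=O)c1ccc(-c2ccccc2Oc2ccc([N+](=O)[O-])c([N+](=O)[O-])c2)s1)Nc1cc(C(F)(F)F)cc(C(F)(F)F)c1` has the lowest of the three numbers measured so far. In a functional assay on HL-60 cells (Homo sapiens) for inhibition, read by CCK-8 assay, with a stated time of 48 h (a higher number here means a weaker inhibitor, a lower number a stronger inhibitor), compound 3 gives 1900 nM. Compound 2 `Cc1ccc(-c2ccsc2S(=O)(=O)NCCNC(=S)Nc2ccc([N+](=O)[O-])cc2)c(Oc2ccc(O)c(O)c2)c1` gives 2900 nM, a gap that lies within the scatter, so these two cannot be ranked against each other. Compound 1 `O=[N+]([O-])c1ccc(NC(=S)N2CCN(S(=O)(=O)c3sccc3-c3ccccc3Oc3ccc(O)c(O)c3)CC2)cc1` gives 5300 nM, a gap beyond the scatter. Compound 4 `O=C(NCCNS(=O)(=O)c1ccc(-c2ccccc2OCc2ccccc2)s1)Nc1cc(C(F)(F)F)cc(C(F)(F)F)c1` has not been measured and differs from compound 3 in one place: benzyl in place of 3,4-dinitrophenyl on an oxygen on an aromatic ring. Among the measured compounds shown here, no measured pair shows this change on its own, so its size and direction are uncertain. Compound 4 is expected to give 3800 nM in this assay, with a range from 1300 nM to 11000 nM. The expected step is a 2.0-fold higher number from compound 3 to compound 4 (0.30 log units; within the scatter), a modest move toward a higher number, barely beyond the scatter.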

Compound 4, half-maximal inhibitory concentration: 11400 nM
Estimate against measurement, compound 4: 3.0-fold (0.48 log units) below; the measured number lies above the stated range.
By their numbers in this assay, from the lowest: compounds 3, 2 and 1 (each within the scatter of the next, the first and the last beyond it); then compound 4.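

Among these compounds, on an oxygen on an aromatic ring, benzyl in place of 3,4-dinitrophenyl is the only single change that can be read here, and in this assay it gives a 6.0-fold higher number from compound 3 to compound 4 (0.78 log units; beyond the scatter) and so a weaker inhibitor. The group at this place therefore matters to the measured inhibition. Nothing shown gives a reason for the step.

This swap removes both nitro groups and also adds a carbon link to the ring. Going by these compounds, what remains open is which of these counts, and a plain phenyl on that oxygen would separate them.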